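Notes on the sulfonamide substituent of compound 2

The source may report more compounds than this note shows. Statements on the series, on what has been measured and on what is new or still open speak of the compounds shown alone.

Measured in a functional assay on HT-29 cells (Homo sapiens) for antiproliferative activity, read by sulforhodamine B assay, with a stated time of 72 h; on this read-out lower numbers stand for stronger inhibition and higher numbers for weaker inhibition:
- compound 1 `S=C(NNc1nncc2ccccc12)Nc1ccccc1`: 40 nM
- compound 2 `O=S(=O)(Nc1nccs1)c1ccc(Nc2nncc3ccccc23)cc1`: 34 nM
- compound 3 `O=C1CS/C(=N/Nc2nncc3ccccc23)N1`: 49 nM

Compound 2 sits within the usual scatter of both other compounds, so these data do not separate it from either. Compound 4 `Cc1cc(NS(=O)(=O)c2ccc(Nc3nncc4ccccc34)cc2)no1` is not yet measured. Its difference from compound 2 is 5-methyl-1,2-oxazol-3-yl in place of 1,3-thiazol-2-yl on a sulfonamide nitrogen. Going by the values given here, no measured pair isolates a change at this place. The expectation in this assay is therefore no shift beyond the scatter, resting on the closeness of compound 1 at 40 nM and compound 3 at 49 nM despite their different structures. The estimated step of a 1.2-fold higher number from compound 2 to compound 4 (0.07 log units; within the scatter) is small. For compound 4 the expected value is 40 nM, with an estimated range of 18 nM to 90 nM.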

Compound 4, half-maximal inhibitory concentration: 23 nM
Estimate against measurement, compound 4: 1.7-fold (0.24 log units) above, within the range that was stated.
By their numbers in this assay, from the lowest: compounds 4, 2, 1 and 3 (each within the scatter of the next, the first and the last beyond it).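

In this assay the replacement of 1,3-thiazol-2-yl by 5-methyl-1,2-oxazol-3-yl on a sulfonamide nitrogen gives a 1.5-fold lower number from compound 2 to compound 4 (0.17 log units; within the scatter) and so does not separate the two groups. Going by these compounds alone, this is the first direct reading at this place: it tolerates this exchange of one five-membered aromatic ring for another without a readable shift. Nothing available bears on what lies behind this result.

Whether the value holds with a ring at this place at all remains open, as the compounds shown carry no plain hydrogen, ethyl chain or phenyl ring on this nitrogen. The role of the methyl on the 1,2-oxazole also stays unresolved, since it is not separated from the change of ring.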